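Cyclohexylmethyl in Place of 4-Fluorophenyl: Expected Cytotoxicity

This account rests on a few compounds, and the source may have more. Where it says the series, first, only, none or still open, it means among the compounds named here.

Compound 1, `COc1cccc(CNCCCNc2ccnc3cc(Oc4ccc(F)cc4)ccc23)c1O`, gives 11000 nM in an ADME assay on HepG2 cells (Homo sapiens) for cytotoxicity, read by luminescence, CellTiter-Glo and ATP content, with a stated time of 72 h; a lower number here means that less compound is needed, a higher number that more compound is needed for the effect.
Compound 2, `COc1cccc(CNCCCNc2ccnc3cc(Oc4ccccc4)ccc23)c1O`, gives 6800 nM in this assay.
Compound 3, `COc1cccc(CNCCCNc2ccnc3cc(-c4ccc(F)cc4)ccc23)c1O`, gives 6840 nM in this assay.

Compound 3 stands second highest of the three numbers, but its neighbours lie close: the steps are a 1.0-fold higher number from compound 2 to compound 3 (0.00 log units; within the scatter) and a 1.6-fold lower number from compound 1 to compound 3 (0.21 log units; within the scatter), so the three measured compounds sit within the scatter of one another and none can be called more or less cytotoxic than the rest.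

Compound 4, `COc1cccc(CNCCCNc2ccnc3cc(CC4CCCCC4)ccc23)c1O`, differs from compound 3 in one place: cyclohexylmethyl in place of 4-fluorophenyl on an aromatic carbon. Among the measured compounds shown here, no measured step involves an exchange of this kind. The three recorded steps, a 1.6-fold lower number from compound 1 to compound 2 (0.21 log units; within the scatter), a 1.6-fold lower number from compound 1 to compound 3 (0.21 log units; within the scatter) and a 1.0-fold higher number from compound 2 to compound 3 (0.00 log units; within the scatter), changed the same site in other ways and all stayed within the scatter. For the measured compounds named here, nothing among the measured compounds therefore argues for a move in either direction, and the expectation rests only on how tightly the three known values cluster. In this assay compound 4 is expected to give about 7000 nM, with a range from 2500 nM to 20000 nM. This estimate means a step of a 1.0-fold higher number from compound 3 to compound 4 (0.01 log units; within the scatter), that is, no change expected beyond the scatter, though the range is kept wide to reflect the absence of any direct precedent.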

Compound 4, half-maximal effective concentration: 970 nM
Beside the measured number, compound 4's estimate is 7.2-fold (0.86 log units) above it; the measured number lies below the stated range.
By their numbers in this assay, from the lowest: compound 4; then compounds 2, 3 and 1 (each within the scatter of the next).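

In this assay this position on the shared core is no longer indifferent: the earlier exchanges there stayed within the scatter, whereas a 7.1-fold lower number from compound 3 to compound 4 (0.85 log units; beyond the scatter) and a 7.0-fold lower number from compound 2 to compound 4 (0.85 log units; beyond the scatter) and an 11-fold lower number from compound 1 to compound 4 (1.05 log units; beyond the scatter) all lie beyond it, so less of compound 4 is needed for the effect. The clearest comparison is with compound 3, where the groups have the same count of heavy atoms and neither has a hydrogen-bond donor or acceptor, yet the six-membered aromatic ring of carbon only gives way to a six-membered non-aromatic ring of carbon only, joined through a single extra carbon. Nothing measured here explains the shift.

With the ring and its carbon link changing together in one step, the compounds shown cannot tell which of the two goes with the lower number. As far as these compounds go, a cyclohexyl group set directly on the aromatic carbon, an open hexyl chain or a piperidinylmethyl group, which carries a ring amine, would each separate these features, and whether any of them would match compound 4 remains open.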